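Dichloro versus amino-chloro cores on chloromethylbenzyl purines

The source may report more compounds than this note shows. Statements on the series, on what has been measured and on what is new or still open speak of the compounds shown alone.

Three compounds carry a chloromethyl-substituted benzyl group on a shared bicyclic core, with a dichloro or amino-chloro pattern on the six-membered ring. In a functional assay on MDA-MB-231 cells (Homo sapiens) for cytotoxicity, read by sulforhodamine B assay, with a stated time of 48 h (on this read-out higher numbers stand for weaker inhibition of growth and lower numbers for stronger inhibition of growth), compound 1 `ClCc1ccccc1Cn1cnc2c(Cl)nc(Cl)nc21` gives 1380 nM, the lowest of the three numbers. Compound 3 `ClCc1cccc(Cn2cnc3nc(Cl)nc(Cl)c32)c1` gives 1730 nM in this assay, a value within the scatter of compound 1, so no order between the two can be stated. For the measured compounds named here, compound 2 `Nc1nc(Cl)c2ncn(Cc3ccc(CCl)cc3)c2n1` gives 34700 nM in this assay, far beyond the scatter from compound 1; compound 2 is the only amino-bearing member measured and also differs in where the chloromethyl group sits on the benzyl ring, so the two changes cannot be separated on these data.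

Compound 4 `Nc1nc(Cl)c2ncn(Cc3ccccc3CCl)c2n1` is compound 1 with amino in place of chloro on an aromatic carbon, and is not yet measured in this assay. Going by the values given here, no single-change step is known between measured compounds. Given the gap between compound 1 at 1380 nM and compound 2 at 34700 nM, a loss beyond the scatter is expected, giving an estimated step of a 14-fold higher number from compound 1 to compound 4 (1.16 log units; beyond the scatter). Compound 4 is expected to give about 20000 nM in this assay, with a range of 5000 nM to 80000 nM.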

Compound 4, concentration for total growth inhibition: 9550 nM
Estimate against measurement, compound 4: 2.1-fold (0.32 log units) above; measured number inside the range.
By their numbers in this assay, from the lowest: compounds 1 and 3 (each within the scatter of the next); then compound 4; then compound 2.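

Amino in place of chloro on this aromatic carbon, between two ring nitrogen atoms, can now be read as a single change: in this assay it gives a 6.9-fold higher number from compound 1 to compound 4 (0.84 log units; beyond the scatter) and lies beyond the scatter, whereas compound 2 carried a second difference and could not separate it. Compound 4 still gives a finite value of 9550 nM on this read-out, so the amino-bearing core with this benzyl group retains a measurable inhibition of growth, though weaker than that of compound 1. Nothing available here explains the size of this step.

From the compounds shown here alone, whether a methoxy, hydroxyl or methylamino group on the same carbon would fall nearer compound 1 or compound 4 remains open. Also open, going by these compounds, is whether the step keeps its size with the chloromethyl group placed as in compound 3 or compound 2.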